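The source may hold more compounds than are shown below. What is called first, only, known or untested is meant among the compounds shown, and "the series" means these compounds.

Compound 1 `Cn1cc(-c2n[nH]c3cc(Cl)c(Br)cc23)cn1` gives 850 nM in an assay on isolated protein for inhibition of tyrosine-protein kinase receptor UFO (Homo sapiens), with a stated time of 1.5 h; on this read-out lower numbers stand for stronger inhibition and higher numbers for weaker inhibition. Compound 2 `Brc1cnn2cccnc12` gives 330000 nM. Compound 3 `Cn1cc(-c2n[nH]c3ccc(Br)cc23)cn1` gives 1540 nM.

On these numbers compound 1 stands lowest of the three. Its nearest neighbour is compound 3, and the step of a 1.8-fold higher number from compound 1 to compound 3 (0.26 log units; within the scatter) lies within the scatter, so the two cannot be ordered. Compound 2, which lacks the shared core of compound 1 and compound 3, lies far beyond the scatter from both.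

Compound 4 `CN1CC[C@@H](Nc2cc3c(-c4cnn(C)c4)n[nH]c3cc2Cl)C1` differs from compound 1 in one place: (1-methylpyrrolidin-3-yl)amino in place of bromo on an aromatic carbon. For the measured compounds named here, the only measured step on the shared core, a 1.8-fold higher number from compound 1 to compound 3 (0.26 log units; within the scatter), concerns the chloro group, which compound 4 keeps, and it tells little about the exchange of the bromo group itself. Going by the values given here, no measured pair shows what the (1-methylpyrrolidin-3-yl)amino group does at this position, so the expectation rests on compound 1 alone and carries a wide range. The estimated step from compound 1 to compound 4 is a 1.2-fold lower number from compound 1 to compound 4 (0.08 log units; within the scatter), which is expected to fall within the scatter. Compound 4 is therefore expected to give 700 nM in this assay, with a range from 120 nM to 4000 nM.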

Compound 4, half-maximal inhibitory concentration: 74000 nM
The estimate for compound 4 lay 110-fold (2.02 log units) below the measured number, outside the stated range (above it).
By their numbers in this assay, from the lowest: compounds 1 and 3 (each within the scatter of the next); then compound 4; then compound 2.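

In this assay, this position on the six-membered aromatic ring, ortho to a chloro group and para to a fused ring, does not tolerate every exchange: with (1-methylpyrrolidin-3-yl)amino in place of bromo, the result is an 87-fold higher number from compound 1 to compound 4 (1.94 log units; beyond the scatter). The earlier compounds offered only one step on the shared core, at the chloro group, and it stayed within the scatter, so this is the first change on that core shown to move the number beyond the scatter. The exchange replaces a single bromine with a group that brings a five-membered non-aromatic ring, a hydrogen-bond donor, hydrogen-bond acceptors and a defined stereocentre, and no evidence is available to say which of these features accounts for the step.

The compounds shown leave open whether a smaller group at this place, such as a plain amine or a methoxy group, would keep the number close to that of compound 1. They also leave open how the opposite stereocentre of the same group, or a pyrrolidine without its methyl, would compare with compound 4.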